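Oxazolyl for Methylpyrazolyl: Agonist Activity Expected to Stay Low

The source may hold more compounds than are shown below. What is called first, only, known or untested is meant among the compounds shown, and "the series" means these compounds.

Three compounds have been measured in a functional assay on CHO cells for agonist activity at Alpha-1B adrenergic receptor (Homo sapiens), read by FLIPR and calcium flux (on this read-out lower numbers stand for an effect already at smaller amounts and higher numbers for an effect only at larger amounts of compound), and each result is a limit of the assay rather than a number:

compound 1 `COc1c(C)ccc2c1CCC2c1ncc[nH]1` gives the limit > 10000 nM
compound 2 `Cc1c(OCC2=NCCN2)ccc(Cl)c1NS(C)(=O)=O` gives the limit > 10000 nM
compound 3 `Cn1nccc1-c1cccc2c1CCC2c1ncc[nH]1` gives the limit > 10000 nM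

Compound 3 therefore stands exactly where the other two stand: at the limit of > 10000 nM in this assay, at which 3 of the 3 values shown sit. All three readings are limits, so no one of them can be called stronger or weaker than another. Going by the values given here, no measured pair differs in just one place, so there is no step between measured compounds to lean on.

Compound 4 `c1cc(-c2ncco2)c2c(c1)C(c1ncc[nH]1)CC2` is the next candidate. It is built from compound 3 by the change (1,3-oxazol-2-yl in place of 1-methyl-1H-pyrazol-5-yl on an aromatic carbon), that is, 1,3-oxazol-2-yl in place of 1-methyl-1H-pyrazol-5-yl on an aromatic carbon. With nothing measured to show how this swap moves the read-out, the expectation is a step that the limit leaves unreadable from compound 3 to compound 4 of no size beyond the usual scatter, in no particular direction. Compound 4 is accordingly expected to come out near 15000 nM, within a range from 3000 nM to 50000 nM, most likely again reported only as a limit.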

Compound 4, half-maximal effective concentration: > 10000 nM
Compound 4 was reported as a limit; the forecaster's own chance of this, stated with the estimate: 80%; the middle value does not contradict the limit.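

Going by these compounds alone, compound 3 and compound 4 are both reported only as limits of the assay, not as numbers, so no step between them can be read, and the swap of 1-methyl-1H-pyrazol-5-yl for 1,3-oxazol-2-yl has no visible size or direction. The compounds shown leave open which change, if any, would give a measurable number in this assay.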